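From Compound 3 to Compound 4: Methoxy Becomes Nitro

This account rests on a few compounds, and the source may have more. Where it says the series, first, only, none or still open, it means among the compounds named here.

Compound 3 `COc1ccc(/C=N/NC(=O)Nc2ccc(Oc3ccnc4cc(OCCCN5CCC(C)CC5)c(OC)cc34)c(F)c2)cc1` was tested in a functional assay on HT-29 cells (Homo sapiens) for cytotoxicity, read by MTT assay, with a stated time of 72 h (on this read-out higher numbers stand for weaker inhibition and lower numbers for stronger inhibition), where compound 3 gives 610 nM. Among the compounds with values here, this is the highest of the three numbers measured so far, but compound 2 `COc1ccc(/C=N/NC(=O)Nc2ccc(Oc3ccnc4cc(OCCCN5CCCCC5)c(OC)cc34)c(F)c2)cc1` gives 590 nM, and the step of a 1.0-fold higher number from compound 2 to compound 3 (0.01 log units; within the scatter) is within the scatter. Compound 1 `COc1cc2c(Oc3ccc(NC(=O)N/N=C/c4ccc([N+](=O)[O-])cc4)cc3F)ccnc2cc1OCCCN1CCCC1` gives 310 nM, which also lies within the scatter of compound 3. Compound 4 `COc1cc2c(Oc3ccc(NC(=O)N/N=C/c4ccc([N+](=O)[O-])cc4)cc3F)ccnc2cc1OCCCN1CCC(C)CC1` has not yet been measured; it differs from compound 3 by nitro in place of methoxy on an aromatic carbon. Within the data shown here, no measured step isolates this change on its own. Compound 1 carries the nitro group and compound 2 the methoxy group, but they differ in the saturated ring as well, and their two values lie within the scatter of each other. The step of a 1.7-fold lower number from compound 3 to compound 4 (0.24 log units; within the scatter) is therefore expected to be small. Compound 4 is estimated at 350 nM, in a range from 150 nM to 800 nM.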

Compound 4, half-maximal inhibitory concentration: 230 nM
Estimate against measurement, compound 4: 1.5-fold (0.18 log units) above; low and high end bracket the measured number.
By their numbers in this assay, from the lowest: compounds 4, 1, 2 and 3 (each within the scatter of the next, the first and the last beyond it).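

With all else held fixed, 4-methoxyphenyl to 4-nitrophenyl gives a 2.7-fold lower number from compound 3 to compound 4 (0.42 log units; beyond the scatter) in this assay, so the group at this position does register in the read-out. Changing the group on the chain instead gives a 1.3-fold lower number from compound 1 to compound 4 (0.13 log units; within the scatter), so with nitro in place, 4-methylpiperidin-1-yl and pyrrolidin-1-yl cannot be told apart here. Nothing measured on hand accounts for the nitro result. As far as these compounds go, how an amine or a nitrile would fare at this position remains open. So does whether the nitro step would repeat with pyrrolidin-1-yl on the chain.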